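The compounds below may be only part of what the source reports. "The series", "measured", "known", "first", "only" and "open" are said of these compounds alone.

For the measured compounds named here, in a functional assay on A549 cells (Homo sapiens) for inhibition, read by MTT assay, with a stated time of 72 h (on this read-out higher numbers stand for weaker inhibition and lower numbers for stronger inhibition), compound 2 (`COc1ccccc1-c1csc2cnc(Nc3cc(F)c(C(=O)NC4CCNCC4)cc3F)nc12`) gives 5390 nM, the highest of the three numbers so far. Compound 3 (`COc1ccccc1-c1csc2cnc(Nc3ccc(C(=O)NCC4CCNCC4)c(F)c3)nc12`) gives 3410 nM, within the scatter of compound 2. Compound 1 (`COc1ccccc1-c1csc2cnc(Nc3ccc(NC(=O)CN)cc3)nc12`) gives 1950 nM, a lower number than compound 2 by a margin beyond the scatter.

Compound 4 (`COc1ccccc1-c1csc2cnc(Nc3ccc(C(=O)NC4CCNCC4)cc3F)nc12`) follows from compound 2 by one change: hydrogen in place of fluoro on an aromatic carbon, with hydrogen in place of fluoro on an aromatic carbon. Going by the values given here, no measured pair isolates this kind of change, so the expectation rests on thin ground. The values of compound 2 at 5390 nM and compound 3 at 3410 nM show no separation, although these two compounds differ in more than one place. No step beyond the scatter is expected in this assay, and no direction is favoured with any confidence.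

The expected change is a 1.3-fold lower number from compound 2 to compound 4 (0.13 log units; within the scatter), a step estimated to stay within the scatter. For compound 4 the estimated value is 4000 nM, with an expected range of 2000 nM to 8000 nM.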

Compound 4, half-maximal inhibitory concentration: 2750 nM
The estimate for compound 4 lay 1.5-fold (0.16 log units) above the measured number; measured number inside the range.
By their numbers in this assay, from the lowest: compounds 1, 4, 3 and 2 (each within the scatter of the next, the first and the last beyond it).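

In this assay, hydrogen in place of the fluoro group ortho to the (piperidin-4-yl)carbamoyl group gives a 2.0-fold lower number from compound 2 to compound 4 (0.29 log units; within the scatter). For the compounds shown here, this is the first step that isolates one change on this aromatic ring, and at this position it does not separate hydrogen from fluoro on this read-out. The data give no measured basis for explaining the step or its size.

Still open, on these data alone, is what a chloro, methoxy or nitrile group on this same aromatic carbon would give in this assay. As far as these compounds go, the role of the remaining fluoro group, para to this position, is also open, since compound 2 and compound 4 both carry it and a step with hydrogen in its place would be needed to read it.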